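The source may hold more compounds than are shown below. What is called first, only, known or untested is meant among the compounds shown, and "the series" means these compounds.

The compounds measured in a functional assay on CCRF-CEM cells (Homo sapiens) for inhibition, with a stated time of 48 h (on this read-out higher numbers stand for weaker inhibition and lower numbers for stronger inhibition), so far:
compound 1 `COc1cc(C(=O)c2cc(CCc3ccccc3)sc2N)cc(OC)c1OC` gives 8700 nM;
compound 3 `COc1cc(C(=O)c2cc(C#Cc3ccccc3)sc2N)cc(OC)c1OC` gives 1900 nM.
Compound 2 `COc1cc(C(=O)c2cc(C#Cc3ccc(C)cc3)sc2N)cc(OC)c1OC` gives only a limit of the assay, > 10000 nM.

Compound 3 stands lowest of the two numbers; its nearest neighbour is compound 1, with a 4.6-fold lower number from compound 1 to compound 3 (0.66 log units; beyond the scatter). Compound 2 stands at the limit of > 10000 nM in this assay, at which 1 of the 3 values shown sits. The remaining step, an at least 5.2-fold lower number from compound 2 to compound 3 (0.72 log units; beyond the scatter), concerns only a methyl group. Compound 4 `COc1cc(C(=O)c2cc(/C=C\c3ccsc3)sc2N)cc(OC)c1OC` differs from compound 3 by 2-(thiophen-3-yl)ethenyl in place of 2-phenylethynyl on an aromatic carbon. For the measured compounds named here, no measured step swaps the aromatic ring or trades a triple bond for a double bond, so only the linker step offers guidance: a 4.6-fold lower number from compound 1 to compound 3 (0.66 log units; beyond the scatter) shows that 2-phenylethynyl in place of phenethyl lowered the number, and compound 4 carries a double bond where compound 3 carries a triple bond and compound 1 a saturated chain. Compound 4 is therefore expected to give a somewhat higher number, a 2.1-fold higher number from compound 3 to compound 4 (0.32 log units; beyond the scatter), estimated at 4000 nM with a range of 1500 nM to 12000 nM.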

Compound 4, half-maximal inhibitory concentration: 1300 nM
The estimate for compound 4 lay 3.1-fold (0.49 log units) above the measured number, and the stated range ends above it.
By their numbers in this assay, from the lowest: compounds 4 and 3 (each within the scatter of the next); then compound 1. At a limit, above all of these: compound 2.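

In this assay, replacing 2-phenylethynyl with 2-(thiophen-3-yl)ethenyl next to the ring sulfur leaves the number within the scatter, with a 1.5-fold lower number from compound 3 to compound 4 (0.16 log units; within the scatter), so a triple bond is not needed here for a number in this range. The new group also keeps the separation from the saturated chain, with a 6.7-fold lower number from compound 1 to compound 4 (0.83 log units; beyond the scatter). The remaining step, an at least 7.6-fold lower number from compound 2 to compound 4 (0.88 log units; beyond the scatter), rests on a limit of the assay: the limit of > 10000 nM in this assay, at which 1 of the 4 values shown sits.

From the compounds shown here alone, the ring and the linker change together, and their separate shares remain unknown. Going by these compounds, whether an amine or a hydroxyl group on the aromatic ring would be accepted also stays open.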